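Removing the trifluoromethyl group from compound 2

This account rests on a few compounds, and the source may have more. Where it says the series, first, only, none or still open, it means among the compounds named here.

Three compounds of the series have numbers in an assay on CHO cells with metabotropic glutamate receptor 2 (Homo sapiens) as the target, read by FLIPR; on this read-out lower numbers stand for an effect already at smaller amounts and higher numbers for an effect only at larger amounts of compound. Compound 1 `CCn1c(CN2CCN(c3nc(C(F)(F)F)ccc3Cl)CC2)nc2ccccc21` gives 63.1 nM, compound 3 `Cn1c(CN2CCN(c3nc4ccccc4s3)CC2)nc2ccccc21` gives 316 nM, and compound 2 `Cn1c(CN2CCN(c3ccc(C(F)(F)F)cn3)CC2)nc2ccccc21` gives 501 nM. Compound 2 stands at the highest number of the three; the gap to compound 3 is within the scatter, the gap to compound 1 is beyond it. Compound 4 `Cn1c(CN2CCN(c3ccccn3)CC2)nc2ccccc21` is not yet measured. It differs from compound 2 in one place, (hydrogen in place of trifluoromethyl on an aromatic carbon), hydrogen in place of trifluoromethyl on an aromatic carbon. For the measured compounds named here, no measured pair shows this step, so its size is open. The expected step is a 2.0-fold higher number from compound 2 to compound 4 (0.30 log units; within the scatter), a moderate rise in number, though a step inside the scatter cannot be excluded. Compound 4 is therefore estimated at 1000 nM, with a range from 300 nM to 3000 nM.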

Compound 4, half-maximal effective concentration: 15800 nM
For compound 4 the middle estimate is 16-fold (1.20 log units) below the measured one, and the stated range ends below it.
By their numbers in this assay, from the lowest: compound 1; then compounds 3 and 2 (each within the scatter of the next); then compound 4.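

In this assay this position on the six-membered aromatic ring, two atoms from the ring nitrogen and para to a large group, proves far from neutral: hydrogen in place of trifluoromethyl gives a 32-fold higher number from compound 2 to compound 4 (1.50 log units; beyond the scatter) and so marks the group as important to the number of compound 2. For the compounds shown here, this is the first single-place change, and its size lies beyond the scatter.

From the compounds shown here alone, whether a methyl group, a methoxy group or a nitrile at this position would keep the number of compound 2 stays open. Nothing at hand accounts for the size of this step.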